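The source may report more compounds than this note shows. Statements on the series, on what has been measured and on what is new or still open speak of the compounds shown alone.

Measured so far in a functional assay on HL-60 cells (Homo sapiens) for antiproliferative activity, read by sulforhodamine B assay, with a stated time of 72 h; on this read-out lower numbers stand for stronger inhibition and higher numbers for weaker inhibition:
compound 1 `Cc1ccccc1NC(=S)N/N=C/c1ccc2ccccc2n1` gives 73200 nM
compound 2 `CN(C)C(=S)N/N=C/c1nc2ccccc2s1` gives 3680 nM
compound 3 `NC(=S)N/N=C/c1ccc2cccnc2n1` gives > 100000 nM

Of the two numbers, compound 1 stands highest; compound 2 sits at the lower number, a gap beyond the scatter. The value of compound 3 is a limit of this assay, not a number (the limit of > 100000 nM in this assay, at which 1 of the 3 values shown sits).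

Compound 4 `COc1ccccc1NC(=S)N/N=C/c1ccc2ccccc2n1` differs from compound 1 by one change (methoxy in place of methyl on an aromatic carbon). Going by the values given here, no measured pair in the set carries this kind of change, so no step in this assay can be read off for it. The expectation for such a swap is a step from compound 1 to compound 4 that stays within the scatter, or at most a small one toward a lower number: a 1.3-fold lower number from compound 1 to compound 4 (0.12 log units; within the scatter). Compound 4 is estimated at 55000 nM, between 18000 nM and 160000 nM.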

Compound 4, half-maximal inhibitory concentration: 91700 nM
Beside the measured number, compound 4's estimate is 1.7-fold (0.22 log units) below it; low and high end bracket the measured number.
By their numbers in this assay, from the lowest: compound 2; then compounds 1 and 4 (each within the scatter of the next). At a limit, above all of these: compound 3.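

Methoxy in place of methyl on this aromatic carbon, ortho to a large group, gives the series its first readable step in this assay, and it is a 1.3-fold higher number from compound 1 to compound 4 (0.10 log units; within the scatter). The added oxygen therefore shifts nothing that can be read at this position, and this pair stays at high numbers. Compound 3 stands at a limit, not a number: the limit of > 100000 nM in this assay, at which 1 of the 4 values shown sits.

Going by these compounds, whether any group here can move the number beyond the scatter remains open, for instance an amine or a carboxylic acid in place of methyl. One pair also leaves open how this swap behaves on another core.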